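Methylsulfonyl in place of chloro: expected cytotoxicity of compound 4

A few compounds are considered here, and "the series" means these few. Any claim that something is new, unique, unknown or untested is made for them only; others in the source may bear on it.

The series shares one core and varies only the ring carried by the amine. Compound 1 `CC1(C)C[C@H](O)C[C@](C)(CNc2ccc(C(F)(F)F)cn2)C1` gives 30500 nM in an ADME assay on MDCK cells (Canis lupus familiaris) for cytotoxicity, read by MTT assay, with a stated time of 3 days; a higher number here means that more compound is tolerated, a lower number that less compound is tolerated. Compound 2 `CC1(C)C[C@H](O)C[C@](C)(CNc2cccc(Cl)c2)C1` gives 9700 nM in this assay, and compound 3 `CC1(C)C[C@H](O)C[C@](C)(CNc2cc(F)cc(Cl)c2)C1` gives 4400 nM.

Compound 2 stands second highest of the three numbers. The nearest step is a 2.2-fold lower number from compound 2 to compound 3 (0.34 log units; beyond the scatter), fluoro in place of hydrogen on an aromatic carbon. Going by the values given here, compound 1 shows the higher number of the two; its structure differs from compound 2 in more than one place, so no single step is drawn between them.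

Compound 4 `CC1(C)C[C@H](O)C[C@](C)(CNc2cccc(S(C)(=O)=O)c2)C1` is not yet measured. It differs from compound 2 by methylsulfonyl in place of chloro on an aromatic carbon, meta to a large group. Among the compounds with values here, no measured step exchanges the chloro itself; the only step on this ring, a 2.2-fold lower number from compound 2 to compound 3 (0.34 log units; beyond the scatter), adds fluoro, is of a different kind, and was modest. The expectation for compound 4 in this assay is therefore a step of uncertain direction that may well stay within the scatter, a somewhat higher number being held slightly more likely. For compound 4 the expected step is a 1.6-fold higher number from compound 2 to compound 4 (0.22 log units; within the scatter). Compound 4 is estimated at 16000 nM, within 6000 nM to 45000 nM.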

Compound 4, half-maximal cytotoxic concentration: > 50000 nM
Compound 4: no number, only a limit; the forecaster's own chance of this, stated with the estimate: 10%; middle value at least 3.1-fold (0.49 log units) from the limit.
By their numbers in this assay, from the lowest: compound 3; then compound 2; then compound 1. At a limit, above all of these: compound 4.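

Going by these compounds alone, exchanging chloro for methylsulfonyl on this aromatic carbon, meta to a large group, gives an at least 5.1-fold higher number from compound 2 to compound 4 (0.71 log units; beyond the scatter) in this assay, whereas the only earlier step on this ring, a 2.2-fold lower number from compound 2 to compound 3 (0.34 log units; beyond the scatter), runs the other way. Within the data shown here, this is the first evidence that replacing the chloro itself, rather than adding to the ring, can move the number clearly upward, so this position is not indifferent to the group it carries. Compound 4, at > 50000 nM, has a limit and not a number, so the upper size of the step stays unknown: the limit of > 50000 nM in this assay, at which 1 of the 4 values shown sits.

Going by these compounds, it remains open whether the step comes from the entering methylsulfonyl or from the departing chloro, a question that hydrogen at this carbon would address, and whether a nitrile or a carboxylic acid at the same place would read in the same direction. Also open is whether methylsulfonyl keeps this effect when the fluoro of compound 3 is on the ring, since the two changes appear together in none of the compounds shown.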